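Replacing 3,4-difluorophenyl with 4-methoxyphenyl in the series

The compounds below may be only part of what the source reports. "The series", "measured", "known", "first", "only" and "open" are said of these compounds alone.

For the measured compounds named here, in a functional assay on HT-29 cells (Homo sapiens) for inhibition, with a stated time of 72 h (a higher number here means a weaker inhibitor, a lower number a stronger inhibitor), compound 1 (`COc1ccc(S(=O)(=O)N2CCc3cccc(-c4ccc(F)nc4)c32)cc1`) gives 109 nM and compound 2 (`COc1ccc(S(=O)(=O)N2CCc3cccc(-c4ccc(F)c(F)c4)c32)cc1`) gives 57 nM, so compound 2 stands within the scatter of the only other number. Compound 3 (`COc1ccc(-c2cccc3c2N(S(=O)(=O)c2ccc(OC)cc2)CC3)cc1`) carries 4-methoxyphenyl in place of 3,4-difluorophenyl on an aromatic carbon. Going by the values given here, one measured step bears on this place, a 1.9-fold lower number from compound 1 to compound 2 (0.28 log units; within the scatter), and it involves a different pair of groups. No step beyond the scatter is therefore expected in this assay, and no direction is favoured. The estimated step is a 1.2-fold higher number from compound 2 to compound 3 (0.09 log units; within the scatter). Compound 3 is expected at 70 nM, with an estimated range of 25 nM to 200 nM.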

Compound 3, half-maximal inhibitory concentration: 277 nM
For compound 3 the middle estimate is 4.0-fold (0.60 log units) below the measured one; measured number above the stated range.
By their numbers in this assay, from the lowest: compounds 2 and 1 (each within the scatter of the next); then compound 3.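

In this assay this position on the shared core now shows a change beyond the scatter: a 4.9-fold higher number from compound 2 to compound 3 (0.69 log units; beyond the scatter) and a 2.5-fold higher number from compound 1 to compound 3 (0.41 log units; beyond the scatter). The two fluorinated groups stayed within the scatter of each other, so the aromatic carbon's substituent had not yet separated any compounds, whereas 4-methoxyphenyl gives the highest number of the three. Nothing available explains this rise. Still open, on these data alone, is whether the rise follows the methoxy group or the absence of fluorine. Unsubstituted phenyl, 4-fluorophenyl and 4-aminophenyl on the same carbon remain unaddressed by the compounds shown.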